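The source may hold more compounds than are shown below. What is called first, only, known or untested is meant among the compounds shown, and "the series" means these compounds.

Compound 1 `COc1ccc(N(C)c2nc(Cl)nc3c2ncn3Cc2cc(OC)cc(OC)c2)cc1` and compound 2 `COc1ccc(N(C)c2nc(Cl)nc3c2ncn3Cc2cc(OC)c(OC)c(OC)c2)cc1` share one core and differ at a single spot: methoxy in place of hydrogen on an aromatic carbon. In a functional assay on K562 cells (Homo sapiens) for antiproliferative activity, read by MTT assay, with a stated time of 48 h (a higher number here means a weaker inhibitor of growth, a lower number a stronger inhibitor of growth), compound 1 gives 42000 nM, while compound 2 gives 41000 nM, so the step of a 1.0-fold lower number from compound 1 to compound 2 (0.01 log units; within the scatter). Compound 3 `COc1ccc(Cn2cnc3c(Cl)ncnc32)cc1` carries a different core; how the two cores differ is not broken down here. In this assay compound 3 reaches only a limit of the assay, > 50000 nM, the point described by the limit of > 50000 nM in this assay, at which 1 of the 3 values shown sits. Compound 4 `COc1ccc(Cn2cnc3c(Cl)ncnc32)cc1OC` has not yet been measured and differs from compound 3 by methoxy in place of hydrogen on an aromatic carbon. Among the compounds with values here, this is the same kind of change as the one from compound 1 to compound 2, though the surroundings differ: in compound 4 the entering group sits ortho to a methoxy group and meta to a large group, whereas in compound 2 it sits ortho to two methoxy groups and para to a large group. Because the earlier step of a 1.0-fold lower number from compound 1 to compound 2 (0.01 log units; within the scatter), the expected step from compound 3 to compound 4 is also small, about a step that the limit leaves unreadable from compound 3 to compound 4. Compound 4 is therefore expected to give roughly 60000 nM in this assay, and most likely again only a limit. The estimated range for compound 4 runs from 30000 nM to 150000 nM.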

Compound 4, concentration for 50% growth inhibition: > 50000 nM
Compound 4: only a limit was reported; the forecaster's own chance of this, stated with the estimate: 70%; the middle value does not contradict the limit.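

Compound 3 and compound 4 both stand at a limit of this assay rather than at a number, so no step between them can be read: the limit of > 50000 nM in this assay, at which 2 of the 4 values shown sit.

The compounds shown leave open what the actual values of compound 3 and compound 4 are, and whether methoxy in place of hydrogen on this core changes growth inhibition at all.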